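This account rests on a few compounds, and the source may have more. Where it says the series, first, only, none or still open, it means among the compounds named here.

Working notes on the series. Within the data shown here, compound 2 `COc1ccc(NC(=O)CCc2nc(Cc3ccc(NC(C)=O)cc3)no2)cc1OC` stands highest of the two numbers so far in a functional assay on the whole organism (strain C57BL/6) for inhibition, with Mus musculus as the target, read by paw edema, with stated times of 1 h and 4 h, at a dose of 100 mg/kg by the oral route; a lower number here means less inhibition, a higher number more inhibition at the dose given (going by the name of the read-out): compound 2 gives 95.9%. Its nearest neighbour is compound 1 `CC(=O)Nc1ccc(Cc2noc(CCC(=O)Nc3ccc(F)cc3F)n2)cc1`, which in this assay gives 52.1%. Among the measured compounds shown here, the single measured step is a number 43.8 percentage points higher from compound 1 to compound 2 (beyond the scatter), a change of 3,4-dimethoxyphenyl in place of 2,4-difluorophenyl on an amide-type nitrogen.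

Compound 3 `CC(=O)Nc1ccc(Cc2noc(CCC(=O)NCc3ccccc3)n2)cc1` differs from compound 2 at the same place: benzyl in place of 3,4-dimethoxyphenyl on an amide-type nitrogen.

For the measured compounds named here, the one step to hand bears on this only indirectly. Going by the values given here, it shows that the group on the amide-type nitrogen can move the read-out in this assay by a large amount, and that 3,4-dimethoxyphenyl went with the higher number; benzyl has no measured counterpart, so its own effect is open. With the 3,4-dimethoxyphenyl removed, the expectation is that compound 3 falls back in this assay by a step of about a number 35.9 percentage points lower from compound 2 to compound 3 (beyond the scatter), a clearly lower number. Among the compounds with values here, compound 3 is therefore estimated at 60% in this assay, with a range from 30% to 85%, the breadth reflecting that only one step informs the guess.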

Compound 3, a percentage reported as inhibition, in the whole organism at one dose (the size of the read-out at that dose, not a potency): 76.7%
For compound 3 the middle estimate is 16.7 percentage points below the measured one, within the range that was stated.
By their numbers in this assay, from the lowest: compound 1; then compound 3; then compound 2.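

In this assay, benzyl on the amide-type nitrogen sits between the two aryl groups, with a number 19.2 percentage points lower from compound 2 to compound 3 (beyond the scatter) and a number 24.6 percentage points higher from compound 1 to compound 3 (beyond the scatter). The position therefore gives three separate levels across the three compounds, and a high read-out does not depend on keeping the 3,4-dimethoxyphenyl, as benzyl retains much of the inhibition while carrying no hydrogen-bond acceptors of its own. No supporting data on the origin of these differences are available for this series.

Benzyl differs from 3,4-dimethoxyphenyl both in lacking the two methoxy groups and in how its ring is attached to the nitrogen, so the two steps cannot separate these changes; plain phenyl, 3,4-dimethoxybenzyl or a longer chain such as 2-phenylethyl on the same nitrogen would be needed to do so. The compounds shown also leave open whether this order holds when the acetamide on the other side of the shared core is replaced, for example by a free amine or a carboxylic acid.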